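A few compounds are considered here, and "the series" means these few. Any claim that something is new, unique, unknown or untested is made for them only; others in the source may bear on it.

Three compounds share one core and differ only in the aryl group attached to it. Compound 1 `Cc1cc(-c2cccc(F)c2)c2ncc(CSCCc3ccccc3)n2c1` gives 35 ug/mL in an ADME assay on HEL cells (Homo sapiens) for cytotoxicity, with a stated time of 3 days; on this read-out lower numbers stand for higher toxicity in this test and higher numbers for lower toxicity in this test. Compound 2 `Cc1cc(-c2ccc(O)cc2)c2ncc(CSCCc3ccccc3)n2c1` gives 13.7 ug/mL in this assay, and compound 3 `Cc1cc(-c2cccs2)cn2c(CSCCc3ccccc3)cnc12` gives 32 ug/mL in this assay. Among the three, compound 2 has the lowest number, and its gaps to compound 3 and to compound 1 both lie beyond the scatter. Among the measured compounds shown here, the one measured step at this position is a 2.6-fold lower number from compound 1 to compound 2 (0.41 log units; beyond the scatter).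

Compound 4 `Cc1cc(-c2ccsc2)c2ncc(CSCCc3ccccc3)n2c1` has not yet been measured in this assay. It differs from compound 2 in one place: thiophen-3-yl in place of 4-hydroxyphenyl on an aromatic carbon. For the measured compounds named here, the only measured step that bears on this change is the one from compound 1 to compound 2, in which the 4-hydroxyphenyl arrived and the number fell modestly. Compound 4 removes that 4-hydroxyphenyl again, so a step back upward is expected. Compound 3, whose aryl group also contains sulfur, gives 32 ug/mL, a number close to that of compound 1 and well above that of compound 2. Compound 4 is therefore expected to give about 28 ug/mL, within a range of 14 ug/mL to 55 ug/mL. The step expected for compound 4 is thus a 2.0-fold higher number from compound 2 to compound 4 (0.31 log units; beyond the scatter).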

Compound 4, half-maximal cytotoxic concentration: > 50 ug/mL
Compound 4: only a limit was reported; the forecaster's own chance of this, stated with the estimate: 5%; at least 1.7-fold (0.25 log units) between middle value and limit.
By their numbers in this assay, from the lowest: compound 2; then compounds 3 and 1 (each within the scatter of the next). At a limit, above all of these: compound 4.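

In this assay the entry for compound 4 is a limit of the assay and not a number: the limit of > 50 ug/mL in this assay, at which 1 of the 4 values shown sits. Even so, thiophen-3-yl in place of 4-hydroxyphenyl at this position gives an at least 3.6-fold higher number from compound 2 to compound 4 (0.56 log units; beyond the scatter), so the low number of compound 2 does not carry over to this five-membered ring, and the position tolerates a change of ring size and of hetero atom without the number falling. Against the 3-fluorophenyl group the picture is less firm: the result gives an at least 1.4-fold higher number from compound 1 to compound 4 (0.15 log units; that floor lies within the scatter), and since that floor lies within the scatter, the limit does not by itself separate these two compounds.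

The compounds shown leave open whether the low number of compound 2 goes with the hydroxyl group or with the six-membered ring that carries it, a question that an unsubstituted phenyl or a 4-methoxyphenyl group at this position would address. They also leave open how far the true number of compound 4 lies past its limit, and whether an amine or a carboxylic acid on the aryl ring would lower the number as the hydroxyl-bearing group does.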